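Heteroaryl Exchange on a Shared Core: Compound 4 Expected

The compounds below may be only part of what the source reports. "The series", "measured", "known", "first", "only" and "open" are said of these compounds alone.

Three compounds built on one shared core were examined in a functional assay on HEK293 cells for agonist activity at Bombesin receptor subtype-3 (Homo sapiens), read by luminescence and calcium flux, with a stated time of 10 min; on this read-out lower numbers stand for an effect already at smaller amounts and higher numbers for an effect only at larger amounts of compound. Compound 1 `CCC(C)(C)Cc1c[nH]c(CCc2ccc(-c3cccc(N)n3)cc2)n1` gives 97 nM, compound 2 `CCC(C)(C)Cc1c[nH]c(CCc2ccc(-c3ccncc3)cc2)n1` gives 95 nM, and compound 3 `CCC(C)(C)Cc1c[nH]c(CCc2ccc(-c3cnsc3)cc2)n1` gives 100 nM. Compound 3 stands indistinguishably beside the other two: a 1.0-fold higher number from compound 1 to compound 3 (0.01 log units; within the scatter) and a 1.1-fold higher number from compound 2 to compound 3 (0.02 log units; within the scatter), just as a 1.0-fold lower number from compound 1 to compound 2 (0.01 log units; within the scatter). Compound 4 `CCC(C)(C)Cc1c[nH]c(CCc2ccc(-c3ccc(F)cn3)cc2)n1` differs from compound 3 by 5-fluoropyridin-2-yl in place of 1,2-thiazol-4-yl on an aromatic carbon. All three measured steps concern exchanges of the group at this same aromatic carbon, and none of them moved the number beyond the scatter, so the change to compound 4 is expected to leave the number essentially unchanged, with no change at the digits printed from compound 3 to compound 4 (within the scatter). Compound 4 is therefore estimated at 100 nM, within a range from 40 nM to 250 nM.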

Compound 4, half-maximal effective concentration: 97 nM
Compound 4: the middle estimate sits 1.0-fold (0.01 log units) above what was measured; the measured number falls inside the stated range.
By their numbers in this assay, from the lowest: compounds 2, 1, 4 and 3 (each within the scatter of the next).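

In this assay, 5-fluoropyridin-2-yl joins the earlier groups at this aromatic carbon without separating from them: a 1.0-fold lower number from compound 3 to compound 4 (0.01 log units; within the scatter), a 1.0-fold higher number from compound 2 to compound 4 (0.01 log units; within the scatter) and no change at the digits printed from compound 1 to compound 4 (within the scatter). A ring carrying fluorine thus fits the same flat picture across all four compounds, so this place, para to a large group, has now accepted a fluorine-bearing ring as well. No measurement at hand accounts for this flatness. The compounds shown leave open whether a carboxylic acid or a morpholine ring at this carbon would keep the number, since every group here is an aromatic ring.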